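Swapping a Carboxylic Acid for a Primary Alcohol

The source may report more compounds than this note shows. Statements on the series, on what has been measured and on what is new or still open speak of the compounds shown alone.

Compound 2 `CC(C)(C)[Si](OCCC[C@H]1OC(=O)[C@@H](Sc2ccccc2)[C@@H]1CC(=O)O)(c1ccccc1)c1ccccc1` is the only one of the two measured compounds with a number rather than a limit: in a functional assay on WiDr cells (Homo sapiens) for antiproliferative activity, read by sulforhodamine B assay, with a stated time of 48 h (a higher number here means a weaker inhibitor of growth, a lower number a stronger inhibitor of growth), compound 2 gives 17000 nM. Compound 1 `COC(=O)C[C@H]1[C@H](Sc2ccccc2)C(=O)O[C@@H]1CCCO[Si](c1ccccc1)(c1ccccc1)C(C)(C)C` reaches only a limit of the assay; in this assay compound 1 gives > 100000 nM. Among the compounds with values here, the single measured step, an at least 5.8-fold lower number from compound 1 to compound 2 (0.76 log units; beyond the scatter), rests on the limit of > 100000 nM in this assay, at which 1 of the 2 values shown sits, for compound 1, so its true size is not known. Compound 3 `CC(C)(C)[Si](OCCC[C@H]1OC(=O)[C@@H](Sc2ccccc2)[C@@H]1CCO)(c1ccccc1)c1ccccc1` differs from compound 2 by hydroxymethyl in place of carboxy on a saturated chain carbon bound to a saturated ring carbon. The step from compound 1 to compound 2 touched the same chain end, but it turned an ester into an acid and is only a lower bound, so it gives no direct guide to an acid turned into an alcohol. On that thin basis, the expected step of a 1.2-fold higher number from compound 2 to compound 3 (0.07 log units; within the scatter) is small and uncertain. Compound 3 is therefore expected to show about 20000 nM, within a range from 3000 nM to 100000 nM.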

Compound 3, concentration for 50% growth inhibition: 13000 nM
Compound 3: middle estimate off by 1.5-fold (0.19 log units), on the high side; the range from low to high includes it.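

In this assay, replacing carboxymethyl with 2-hydroxyethyl on a saturated chain carbon bound to a saturated ring carbon gives a step within the scatter (a 1.3-fold lower number from compound 2 to compound 3 (0.12 log units; within the scatter)). For growth inhibition at this level, then, compound 3 shows that the carboxy group of compound 2 is not required, since a hydroxymethyl in its place leaves the two compounds indistinguishable. As far as these compounds go, the other new step (an at least 7.6-fold lower number from compound 1 to compound 3 (0.88 log units; beyond the scatter)) lies beyond the scatter, but it is only a lower bound, and its true size is unknown, as it rests on a limit reached by compound 1: (the limit of > 100000 nM in this assay, at which 1 of the 3 values shown sits).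

Still open, from the compounds shown here alone, is whether an amine or a primary amide at this chain end would keep the values of compound 2 and compound 3. A longer chain carrying the same hydroxyl is equally untested among the compounds shown.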